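From methyl to fluoro: estimating compound 3

This account rests on a few compounds, and the source may have more. Where it says the series, first, only, none or still open, it means among the compounds named here.

- compound 1 `COc1ccc(C/N=C2\NC(=O)/C(=C3\CCNC(=O)c4[nH]ccc43)S2)cc1`: 12100 nM
- compound 2 `Cc1ccc(C/N=C2\NC(=O)/C(=C3\CCNC(=O)c4[nH]ccc43)S2)cc1`: 4150 nM
- compound 3 `O=C1N/C(=N\Cc2ccc(F)cc2)S/C1=C1/CCNC(=O)c2[nH]ccc21`: not yet measured

Among the compounds with values here, in a functional assay on SK-MEL-28 cells (Homo sapiens) for inhibition, read by MTT assay, with a stated time of 48 h (a higher number here means a weaker inhibitor, a lower number a stronger inhibitor), compound 2 has the lower of the two numbers so far, 4150 nM, which makes it the stronger inhibitor. The next change is fluoro in place of methyl on an aromatic carbon, para to a large group. Within the data shown here, only one measured step bears on this, the swap of methoxy for methyl on the same aromatic carbon, a 2.9-fold lower number from compound 1 to compound 2 (0.46 log units; beyond the scatter). Among the measured compounds shown here, that step is modest, and no measured compound carries fluoro, so the data fix no direction. A step of similar or smaller size is expected in this assay, with a slight lean towards a higher number. The estimated change is a 1.4-fold higher number from compound 2 to compound 3 (0.16 log units; within the scatter). For compound 3 the expected value is 6000 nM, within an estimated range of 2200 nM to 16000 nM.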

Compound 3, half-maximal inhibitory concentration: 11200 nM
The estimate for compound 3 lay 1.9-fold (0.27 log units) below the measured number; the measured number falls inside the stated range.
By their numbers in this assay, from the lowest: compound 2; then compounds 3 and 1 (each within the scatter of the next).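

In this assay, fluoro in place of methyl gives a 2.7-fold higher number from compound 2 to compound 3 (0.43 log units; beyond the scatter), so exchanging one heavy atom for another at this spot on the ring is enough to move the number beyond the scatter. Fluoro and methoxy cannot be told apart, with a 1.1-fold lower number from compound 1 to compound 3 (0.03 log units; within the scatter), which leaves methyl in compound 2 as the only one of the three groups whose number stands clear of the other two. Nothing measured here gives a reason for methyl standing apart.

Three groups at one position are too few to show a trend, so this could be a feature of methyl alone or part of a wider pattern. On these data alone, whether chloro, an amine or a longer chain such as ethyl would match methyl, or instead fall in with fluoro and methoxy, remains open.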